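Swapping Ethoxycarbonyl for Sulfamoyl in a Cell Assay

This account rests on a few compounds, and the source may have more. Where it says the series, first, only, none or still open, it means among the compounds named here.

Measured so far in a functional assay on WiDr cells (Homo sapiens) for inhibition; a lower number here means a stronger inhibitor, a higher number a weaker inhibitor
- compound 1 `CCOC(=O)c1ccc(NC(=O)N2CC2C#N)cc1` gives 2500 nM
- compound 2 `N#CC1CN1C(N)=O` gives > 280000 nM (a limit of the assay)

Within the data shown here, only one real number is available here. Among the measured compounds shown here, compound 1 gives 2500 nM in this assay and so is the sole compound with a measured potency. For compound 2 the assay reports > 280000 nM as a limit and not as a number.

The next compound is compound 3 `N#CC1CN1C(=O)Nc1ccc(S(N)(=O)=O)cc1`, which has not been measured yet. It keeps the core of compound 1 and carries sulfamoyl in place of ethoxycarbonyl on an aromatic carbon in the same place.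

For the measured compounds named here, no measured pair shows what this swap does, so any forecast is loose. Starting from compound 1 at 2500 nM as the only anchor, a moderate loss of strength in this assay seems more likely than a gain, though a result within the scatter would not be surprising. The expected change is a 2.8-fold higher number from compound 1 to compound 3 (0.45 log units; beyond the scatter) and remains an estimate. For compound 3 the estimated value is 7000 nM with an expected range from 1500 nM to 35000 nM in this forecast.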

Compound 3, half-maximal inhibitory concentration: > 38000 nM
Compound 3: a limit, no number; the forecaster's own chance of this, stated with the estimate: 10%; at least 5.4-fold (0.73 log units) between middle value and limit.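

Sulfamoyl in place of ethoxycarbonyl on an aromatic carbon gives the first step with a readable size at this position in this assay, and it is an at least 15-fold higher number from compound 1 to compound 3 (1.18 log units; beyond the scatter). This shows that the position is not indifferent to what it carries: on the same core, the two groups do not give the same result, and ethoxycarbonyl is the one that leaves a measurable potency. Compound 3 gives > 38000 nM in this assay, which is a limit of the assay and not a number, so the step is only a minimum because it rests on that limit: the limit of > 38000 nM in this assay, at which 1 of the 3 values shown sits.

From the compounds shown here alone, how much weaker compound 3 really is stays open, and so does whether any inhibition remains at higher concentrations. With only these two groups compared at this position, it is also unclear which part of ethoxycarbonyl matters, and a carboxylic acid, a simple amide or a plain methyl group in the same place would help to separate the ester from other small groups.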